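The source may report more compounds than this note shows. Statements on the series, on what has been measured and on what is new or still open speak of the compounds shown alone.

Measured in an ADME assay on HepG2 cells (Homo sapiens) for cytotoxicity, read by luminescence, with a stated time of 72 h; on this read-out lower numbers stand for an effect already at smaller amounts and higher numbers for an effect only at larger amounts of compound:
- compound 1 `CCOC(=O)c1c(-c2cccc(OC)c2)[nH]c2cc(OC)c(F)cc2c1=O`: > 21500 nM (a limit)
- compound 2 `CCOC(=O)c1c(-c2cccc(Br)c2)[nH]c2cc(OC)c(F)cc2c1=O`: > 21500 nM (a limit)

Compound 2 has no number to its name in this assay, only a limit of the assay. Compound 1 also reaches only a limit. What is known so far is therefore (the limit of > 21500 nM in this assay, at which 2 of the 2 values shown sit).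

Compound 3 `CCOC(=O)c1c(-c2cccc(-c3c(C)cccc3C)c2)[nH]c2cc(OC)c(F)cc2c1=O` has 2,6-dimethylphenyl in place of bromo on an aromatic carbon, meta to a large group: 2,6-dimethylphenyl in place of bromo on an aromatic carbon. For the measured compounds named here, the one measured step that bears on this change is a step that the two limits leave unreadable from compound 1 to compound 2. It also exchanges a group on an aromatic carbon, but it offers no size to carry over.

The expectation therefore rests on where compound 2 sits, which is the limit of > 21500 nM. No step beyond the usual scatter is expected, although the entering ring has not yet been tested in this assay, so a measurable value remains possible. The estimated change is an at least 1.0-fold lower number from compound 2 to compound 3 (0.03 log units; that floor lies within the scatter). For compound 3 the estimate is 20000 nM, with an expected range from 9000 nM to 30000 nM.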

Compound 3, half-maximal effective concentration: > 21500 nM
Compound 3: no number, only a limit; the forecaster's own chance of this, stated with the estimate: 65%; middle value at least 1.0-fold (0.03 log units) from the limit.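

In this assay compound 3 gives > 21500 nM as a limit, not a number. For the compounds shown here, the steps from compound 2 to compound 3 and from compound 1 to compound 3 cannot be read, so these compounds yield no new step. The compounds shown leave open how their values would compare in this assay if measured beyond the one limit they share: the limit of > 21500 nM in this assay, at which 3 of the 3 values shown sit.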